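The source may hold more compounds than are shown below. What is called first, only, known or untested is meant among the compounds shown, and "the series" means these compounds.

Measured so far:
compound 1, `S=C(N/N=C/c1ccc(Oc2ccc(Cl)cc2)cc1)Nc1ccccc1`, 5.52
compound 2, `O=[N+]([O-])c1ccc(Oc2ccc(/C=N/NC(=S)Nc3ccccc3)cc2)cc1`, 4.95
compound 3, `Cc1ccc(Oc2ccc(/C=N/NC(=S)Nc3ccccc3)cc2)cc1`, 5.39

These three compounds share one core and differ only in the group on the outer ring of the ether. In a physicochemical assay for lipophilicity, in phosphate buffer, measured as octanol-water partition, with a stated time of 24 h (a lower number here means a more polar compound, a higher number a more lipophilic compound), compound 1 gives the highest of the three numbers. Its neighbour is compound 3, since a number 0.13 log units lower from compound 1 to compound 3 (within the scatter), which is within the scatter; the only clear separation is a number 0.57 log units lower from compound 1 to compound 2 (beyond the scatter).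

Compound 4, `S=C(N/N=C/c1ccc(Oc2ccc(Cl)cc2)cc1)Nc1ccc(Cl)cc1`, has not yet been measured in this assay. It differs from compound 1 in one place: chloro in place of hydrogen on an aromatic carbon. The change sits on the aniline side of the core, on an aromatic carbon of a six-membered aromatic ring of carbon only, para to a large group.

Among the measured compounds shown here, no measured step here replaces hydrogen by chloro, so the bearing of the known steps is indirect. They show that the chloro compound stands at the top, with a number 0.44 log units higher from compound 2 to compound 3 (beyond the scatter) and a number 0.57 log units lower from compound 1 to compound 2 (beyond the scatter) marking the range within which these three compounds lie. Adding a second chloro to compound 1 is therefore expected to raise the number in this assay by a modest step, a number 0.48 log units higher from compound 1 to compound 4 (beyond the scatter). Compound 4 is estimated at 6, with an expected range from 5.6 to 6.5.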

Compound 4, partition coefficient: 6.2
The estimate for compound 4 lay 0.20 log units below the measured number; the range from low to high includes it.
By their numbers in this assay, from the lowest: compound 2; then compounds 3 and 1 (each within the scatter of the next); then compound 4.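

Compound 4 brings the only change shown at the anilino end of the shared core, where phenyl becomes 4-chlorophenyl, whereas compounds 1, 2 and 3 differ only on the outer ring of the ether. In this assay, chloro in place of hydrogen on this aromatic carbon, para to a large group, gives a number 0.68 log units higher from compound 1 to compound 4 (beyond the scatter), so this end of the molecule also affects the number, and a single added chlorine atom is enough to move it beyond the scatter. The compounds shown offer no evidence for why the number rises at this position.

With only one substituent shown at this carbon, it remains open how an amine, a carboxylic acid or a longer chain there would compare with chloro, and whether any of them would lower the number instead of raising it. Going by these compounds, it is also open whether the same hydrogen-to-chloro change would give a step of similar size on the core of compound 2 or compound 3, which carry nitro and methyl on the outer ring in place of chloro.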